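The compounds below may be only part of what the source reports. "The series", "measured", "known", "first", "only" and "open" are said of these compounds alone.

Among the measured compounds shown here, compound 2 `Cc1ccc(C(=O)Nc2nccn3cc(-c4ccccc4)nc23)cc1` gives 26% in an assay on cells for displacement of a labelled ligand from adenosine receptor A1 (Homo sapiens), read by scintillation counting, with a stated time of 120 min, tested at 1 uM (a higher number here means more inhibition at the concentration tested (going by the name of the read-out), a lower number less inhibition), the higher of the two numbers measured so far. Compound 1 `COc1ccc(C(=O)Nc2nccn3cc(-c4ccccc4)nc23)cc1` gives 1% in this assay, and the step of a number 25 percentage points higher from compound 1 to compound 2 (beyond the scatter) is the only one measured. Compound 3 `O=C(Nc1nccn2cc(-c3ccccc3)nc12)c1ccco1` differs from compound 2 in another place: furan-2-yl in place of 4-methylphenyl on a carbonyl carbon. The measured step only changed a group on the six-membered aromatic ring, not that ring itself, so it bears on the present change only loosely; it does show that a change on this side of the amide can move the read-out by a modest amount. Nothing measured here tells the direction for exchanging the whole ring. Compound 3 is therefore estimated to give about 15%, in a range of 0% to 35%, which would be a step of a number 11 percentage points lower from compound 2 to compound 3 (beyond the scatter) expected to stay within or only just beyond the scatter.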

Compound 3, a percentage reported as inhibition, at one concentration (the size of the read-out at that concentration, not a potency): 25%
Beside the measured number, compound 3's estimate is 10 percentage points below it; measured number inside the range.
By their numbers in this assay, from the lowest: compound 1; then compounds 3 and 2 (each within the scatter of the next).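

In this assay, the step is a number 1 percentage points lower from compound 2 to compound 3 (within the scatter), so on this carbonyl carbon the six-membered aromatic ring of 4-methylphenyl can give way to the five-membered aromatic ring of furan-2-yl without a change that leaves the scatter. Among the compounds shown here, the other new step is a number 24 percentage points higher from compound 1 to compound 3 (beyond the scatter), which makes 4-methoxyphenyl the one group of the three at this position whose compound stands apart, while the earlier pair could only show a change of group on an unchanged ring. No measurement available here accounts for either step.

The compounds shown leave open how a saturated ring such as cyclohexyl, or an open chain such as butyl, would read at this carbonyl carbon. They also leave open what a chlorine or an amine on the furan ring would do.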